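Chlorine Added to a Second Core

The source may report more compounds than this note shows. Statements on the series, on what has been measured and on what is new or still open speak of the compounds shown alone.

Compound 1 `COc1cc(Br)cc(/C=C/C(=O)c2ccccc2)c1O` and compound 2 `COc1cc(Br)cc(/C=C/C(=O)c2ccc(Cl)cc2)c1O` share one core, and compound 2 carries chloro in place of hydrogen on an aromatic carbon. In a functional assay on MCF7 cells (Homo sapiens) for antiproliferative activity, read by sulforhodamine B assay, with a stated time of 72 h, tested at 30 uM (on this read-out lower numbers stand for a stronger effect and higher numbers for a weaker effect at the one concentration tested), compound 1 gives 28.1% and compound 2 gives 28%; this change made a number 0.1 percentage points lower from compound 1 to compound 2 (within the scatter), so the two results cannot be told apart. Compound 3 `COC(=O)C1=C(N)Oc2ccc(Br)cc2C1CC(=O)c1ccccc1` is built on a different core, and how that core differs from the core of compound 1 is not broken down here. In this assay compound 3 gives 41.3%, a number that lies beyond the scatter from the numbers of both compound 1 and compound 2. Compound 4 `COC(=O)C1=C(N)Oc2ccc(Br)cc2C1CC(=O)c1ccc(Cl)cc1` has not been measured yet. Among the compounds with values here, it differs from compound 3 by chloro in place of hydrogen on an aromatic carbon, which is the same change, at the same place, as the one that turns compound 1 into compound 2. Within the data shown here, the only guide is that earlier pair, where a number 0.1 percentage points lower from compound 1 to compound 2 (within the scatter) amounted to nothing beyond the scatter. The expected step is therefore a number 0.3 percentage points lower from compound 3 to compound 4 (within the scatter). Compound 4 is expected to give 41%, between 30% and 53%.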

Compound 4, a percentage reported as activity, at one concentration (the size of the read-out at that concentration, not a potency): 32.4%
Estimate against measurement, compound 4: 8.6 percentage points above, within the range that was stated.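

In this assay, within the data shown here, placing chloro on the aromatic carbon of the second core gives a number 8.9 percentage points lower from compound 3 to compound 4 (within the scatter), so on this core too the change produces no step that can be told from the usual scatter. Set side by side, the two steps also cannot be told apart: the same change on two cores in this assay, a number 0.1 percentage points lower (within the scatter) from compound 1 to compound 2 and a number 8.9 percentage points lower (within the scatter) from compound 3 to compound 4, 8.8 percentage points apart, within the scatter of two such steps

Among these compounds, this shows that, as far as these two pairs can tell, phenyl to 4-chlorophenyl behaves alike on both cores, but it does not show that the chloro has no effect, since each core offers only one pair, read at one concentration, and a real but small effect could hide inside the scatter.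

The compounds shown leave open how a fluoro, a methoxy, an amine or a carboxylic acid would behave in the place of the chloro on either core. They also leave open whether the same change would carry over to any core beyond these two.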